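The source may report more compounds than this note shows. Statements on the series, on what has been measured and on what is new or still open speak of the compounds shown alone.

Compound 3 `CCOc1ccccc1NC1=CC(=O)c2c(nc3n2[C@H]2OC[C@@H](O)[C@H]2OC3)C1=O` sits alongside compound 1 `O=C1C(Nc2cccc(Cl)c2)=CC(=O)c2c1nc1n2[C@H]2OC[C@@H](O)[C@H]2OC1` and compound 2 `O=C1C(N2CCCCC2)=CC(=O)c2c1nc1n2[C@H]2OC[C@@H](O)[C@H]2OC1` in this series. In a functional assay on HeLa cells (Homo sapiens) for inhibition, read by sulforhodamine B assay (on this read-out lower numbers stand for stronger inhibition and higher numbers for weaker inhibition), compound 3 gives 8300 nM, the higher of the two numbers recorded; compound 1 gives 7970 nM. The step is a 1.0-fold higher number from compound 1 to compound 3 (0.02 log units; within the scatter). For compound 2 the assay reports only a limit, > 16000 nM. Compound 4 `O=C1C(Nc2ccc(Br)cc2)=CC(=O)c2c1nc1n2[C@H]2OC[C@@H](O)[C@H]2OC1` changes the aryl group again: 4-bromophenyl in place of 2-ethoxyphenyl on an amine nitrogen. The step bearing directly on this change is a 1.0-fold higher number from compound 1 to compound 3 (0.02 log units; within the scatter), an aryl swap with no shift beyond the scatter; an at least 2.0-fold higher number from compound 1 to compound 2 (0.30 log units; that floor lies within the scatter) concerns a different change and ends at a limit. The expected step is therefore a 1.1-fold lower number from compound 3 to compound 4 (0.04 log units; within the scatter), none beyond the scatter. Compound 4 is expected to give about 7500 nM, estimated between 3500 nM and 16000 nM.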

Compound 4, half-maximal inhibitory concentration: 5220 nM
Beside the measured number, compound 4's estimate is 1.4-fold (0.16 log units) above it, within the range that was stated.
By their numbers in this assay, from the lowest: compounds 4, 1 and 3 (each within the scatter of the next). At a limit, above all of these: compound 2.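

In this assay, the 4-bromophenyl group on the amine nitrogen gives no separation from the other aryl groups: a 1.6-fold lower number from compound 3 to compound 4 (0.20 log units; within the scatter) and a 1.5-fold lower number from compound 1 to compound 4 (0.18 log units; within the scatter). With 4-bromophenyl, 3-chlorophenyl and 2-ethoxyphenyl, three arylamino compounds now sit within the scatter of one another. Among the compounds shown here, compound 2 stands at a limit, so only a floor can be read, an at least 3.0-fold lower number from compound 2 to compound 4 (0.48 log units; beyond the scatter), the first step on this double-bonded ring carbon beyond the scatter.

Open, from the compounds shown here alone, is whether a benzylamino or morpholin-4-yl group on this carbon would follow the arylamino compounds or compound 2. Also open, going by these compounds, is whether a carboxylic acid on the aryl ring would move the number beyond the scatter.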